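Aryl swaps on the amine: from compound 3 to compound 4

The source may hold more compounds than are shown below. What is called first, only, known or untested is meant among the compounds shown, and "the series" means these compounds.

Measured in a functional assay on U-87MG ATCC cells for antiproliferative activity against U-87 MG (Homo sapiens), read by spectrophotometry, with a stated time of 2 days; a lower number here means a stronger inhibitor of growth, a higher number a weaker inhibitor of growth:
- compound 1 `COc1ccc(Nc2ncc(C(F)(F)F)c(N3Cc4cccc(N(C)S(C)(=O)=O)c4C3)n2)cc1C(F)(F)F`: 29400 nM
- compound 2 `Cc1ccc(Nc2ncc(C(F)(F)F)c(N3Cc4cccc(N(C)S(C)(=O)=O)c4C3)n2)c(Cl)c1`: > 30000 nM (a limit)
- compound 3 `Cc1cc(F)ccc1Nc1ncc(C(F)(F)F)c(N2Cc3cccc(N(C)S(C)(=O)=O)c3C2)n1`: > 30000 nM (a limit)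

Compound 3 gives > 30000 nM, which is a limit and not a number. This is the limit of > 30000 nM in this assay, at which 2 of the 3 values shown sit.

Compound 4 `COc1cc(Nc2ncc(C(F)(F)F)c(N3Cc4cccc(N(C)S(C)(=O)=O)c4C3)n2)cc(C(F)(F)F)c1` differs from compound 3 by one change: 3-methoxy-5-(trifluoromethyl)phenyl in place of 4-fluoro-2-methylphenyl on a nitrogen on an aromatic ring.

Three measured steps change the group at that place. The first two are an at least 1.0-fold higher number from compound 1 to compound 2 (0.00 log units; that floor lies within the scatter) and an at least 1.0-fold higher number from compound 1 to compound 3 (0.00 log units; that floor lies within the scatter), and both floors lie within the scatter. The third is a step that the two limits leave unreadable from compound 2 to compound 3. Among the measured compounds shown here, compound 1, with 4-methoxy-3-(trifluoromethyl)phenyl, is the only compound with a number, 29400 nM. These steps give no ground for expecting a change beyond the scatter in this assay, in either direction. The estimated step is an at least 1.0-fold lower number from compound 3 to compound 4 (0.02 log units; that floor lies within the scatter). A reading at the limit is about as likely as a number. For compound 4 the expected value is 28000 nM, with an estimated range from 12000 nM to 30000 nM.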

Compound 4, concentration for 50% growth inhibition: > 30000 nM
Compound 4: no number, only a limit; the forecaster's own chance of this, stated with the estimate: 50%; at least 1.0-fold (0.02 log units) between middle value and limit.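

In this assay compound 4 gives > 30000 nM, which is a limit and not a number. The 3-methoxy-5-(trifluoromethyl)phenyl group carries the same two substituents as the 4-methoxy-3-(trifluoromethyl)phenyl group of compound 1, and the change gives an at least 1.0-fold higher number from compound 1 to compound 4 (0.00 log units; that floor lies within the scatter). The steps to compound 4 from compound 2 and from compound 3 join two limits and cannot be read, so the four aryl groups on this nitrogen stay unseparated in this assay: the limit of > 30000 nM in this assay, at which 3 of the 4 values shown sit.

Going by these compounds, whether any group at this place gives a number clearly lower than that of compound 1 stays open, for instance an aryl ring carrying a dimethylamino group or a carboxylic acid. On these data alone, whether compound 2, compound 3 and compound 4 differ from one another at all also stays open.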